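The source may hold more compounds than are shown below. What is called first, only, known or untested is meant among the compounds shown, and "the series" means these compounds.

Three close relatives of one shared core have been tested in a functional assay on CEM-DNR-bulk cells (Homo sapiens), read by MTT assay, with a stated time of 72 h; on this read-out higher numbers stand for weaker inhibition and lower numbers for stronger inhibition. Compound 1 `COc1ncnc2c1c(-c1ccoc1)cn2[C@@H]1O[C@H](CO)[C@@H](O)[C@H]1O` carries a methoxy group on an aromatic carbon; in this assay compound 1 gives > 20000 nM, which is a limit of the assay rather than a number. Compound 2 `CN(C)c1ncnc2c1c(-c1ccoc1)cn2[C@@H]1O[C@H](CO)[C@@H](O)[C@H]1O` has dimethylamino in place of methoxy on that carbon, and compound 2 likewise gives only the limit > 20000 nM. Compound 3 `Cc1ncnc2c1c(-c1ccoc1)cn2[C@@H]1O[C@H](CO)[C@@H](O)[C@H]1O` has methyl in place of methoxy, and compound 3 also gives the limit > 20000 nM. The steps between these three, a step that the two limits leave unreadable from compound 1 to compound 2, a step that the two limits leave unreadable from compound 1 to compound 3 and a step that the two limits leave unreadable from compound 2 to compound 3, therefore cannot be sized, because of the limit of > 20000 nM in this assay, at which 3 of the 3 values shown sit. Compound 3 thus stands at the same limit as the other two, and nothing separates it from them on the numbers shown.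

Compound 4 `CSc1ncnc2c1c(-c1ccoc1)cn2[C@@H]1O[C@H](CO)[C@@H](O)[C@H]1O` is the unmeasured relative; it differs from compound 3 by methylsulfanyl in place of methyl on an aromatic carbon. For the measured compounds named here, none of the measured steps reads as a number, so none shows whether a change of this kind moves the value in either direction. With three limit values and no readable step, compound 4 is expected to sit at the limit too, and the step that the limit leaves unreadable from compound 3 to compound 4 is an estimate of no change. The value of compound 4 in this assay is estimated at 30000 nM, in a range from 10000 nM to 100000 nM.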

Compound 4, half-maximal inhibitory concentration: > 20000 nM
Compound 4: no number, only a limit (the forecaster's own chance of this, stated with the estimate: 80%); the middle value does not contradict the limit.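

Compound 4 joins compound 1, compound 2 and compound 3 at the same limit of the assay, so no step among these four compounds can be read: the limit of > 20000 nM in this assay, at which 4 of the 4 values shown sit.

The compounds shown leave open whether changing the group on this aromatic carbon moves the value in this assay at all, and in which direction.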